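The compounds below may be only part of what the source reports. "The series", "measured", "known", "first", "only" and "open" are said of these compounds alone.

Measured so far:
- compound 1 (`CN(Cc1ccccc1)C(=O)c1cc2c(Cc3ccccc3)n[nH]c2cc1O`): 980 nM
- compound 2 (`CN(Cc1ccccc1)C(=O)c1cc2c(Cc3ccccc3Cl)n[nH]c2cc1O`): "not determined" (no result reported)

For the measured compounds named here, in a functional assay on A2780 cells (Homo sapiens) for antiproliferative activity, read by resazurin assay, with a stated time of 72 h (on this read-out lower numbers stand for stronger inhibition and higher numbers for weaker inhibition), compound 1 gives the only number (980 nM). Compound 2 has no place on that scale, since its entry reads "not determined" (no result reported) and no result exists for it. Compound 3 (`CN(Cc1ccccc1)C(=O)c1cc2c(Cc3cccc(F)c3)n[nH]c2cc1O`) is still unmeasured. The structural change (3-fluorophenyl in place of 2-chlorophenyl on a saturated chain carbon bound to an aromatic carbon) puts 3-fluorophenyl in place of 2-chlorophenyl on a saturated chain carbon bound to an aromatic carbon. Going by the values given here, no measured step shows what a change at this place does. A large step in this assay is therefore not expected, in either direction, and compound 1 at 980 nM remains the sole anchor. Compound 3 is estimated at 800 nM in this assay, with an expected range from 300 nM to 2500 nM as the likely span.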

Compound 3, half-maximal inhibitory concentration: 1700 nM
Beside the measured number, compound 3's estimate is 2.1-fold (0.33 log units) below it; low and high end bracket the measured number.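

In this assay, for the compounds shown here, fluoro in place of hydrogen on an aromatic carbon gives a 1.7-fold higher number from compound 1 to compound 3 (0.24 log units; within the scatter), the first reading of a change at this place, and this single pair shows that the 3-fluorobenzyl group leaves the result within the usual scatter. The change from 2-chlorophenyl to 3-fluorophenyl cannot be read, as compound 2 has no result. No measurement on hand bears on why fluoro at this place gives this outcome.

Going by these compounds, whether the 2-chlorobenzyl group of compound 2 would differ from the unsubstituted benzyl group of compound 1 remains open. Also open, on these data alone, is whether an amine or a carboxylic acid on this aromatic ring, or a longer chain in place of the saturated chain carbon, would produce a step beyond the scatter.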